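The compounds below may be only part of what the source reports. "The series", "measured", "known", "first", "only" and "open" are said of these compounds alone.

Of the compounds shown here, three with a shared core have been measured in a functional assay on HeLa cells (Homo sapiens) for cytotoxicity, read by sulforhodamine B assay; a lower number here means a stronger inhibitor, a higher number a weaker inhibitor. Compound 1 `Cc1ccccc1S(=O)(=O)NC(C)C1=CC(=O)c2c(O)ccc(O)c2C1=O` gives 4490 nM, compound 2 `CC(NS(=O)(=O)c1ccc(F)cc1)C1=CC(=O)c2c(O)ccc(O)c2C1=O` gives 6410 nM and compound 3 `CC(NS(=O)(=O)c1ccc(Br)cc1)C1=CC(=O)c2c(O)ccc(O)c2C1=O` gives 5210 nM. Compound 3 therefore stands level with the other two, its value lying within the scatter of both.

Compound 4 `CC(NS(=O)(=O)c1cccc(Br)c1)C1=CC(=O)c2c(O)ccc(O)c2C1=O` has the same atoms as compound 3, joined differently, with 3-bromophenyl in place of 4-bromophenyl on a sulfonyl sulfur.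

Within the data shown here, no measured pair tests this exact change. The closest evidence comes from the three steps that alter the group on the sulfonyl sulfur. These are a 1.4-fold higher number from compound 1 to compound 2 (0.15 log units; within the scatter), a 1.2-fold higher number from compound 1 to compound 3 (0.06 log units; within the scatter) and a 1.2-fold lower number from compound 2 to compound 3 (0.09 log units; within the scatter). All three are small, so the group has so far made no measurable difference among these compounds, though three compounds are a thin basis and a new arrangement could behave otherwise.

No step beyond the scatter is therefore expected in this assay, and no direction is favoured. The expected step is a 1.0-fold lower number from compound 3 to compound 4 (0.00 log units; within the scatter). The estimate for compound 4 is 5200 nM, with an expected range from 3000 nM to 9000 nM.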

Compound 4, half-maximal inhibitory concentration: 6350 nM
Compound 4: the middle estimate sits 1.2-fold (0.09 log units) below what was measured, and the stated range covers the measured number.
By their numbers in this assay, from the lowest: compounds 1, 3, 4 and 2 (each within the scatter of the next).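

Moving the bromine, with 3-bromophenyl in place of 4-bromophenyl on a sulfonyl sulfur, is the first change in this set that keeps the same atoms and alters only how they are joined, and in this assay it gives a 1.2-fold higher number from compound 3 to compound 4 (0.09 log units; within the scatter) as the step. The comparisons with the two other groups are equally small, with a 1.0-fold lower number from compound 2 to compound 4 (0.00 log units; within the scatter) and a 1.4-fold higher number from compound 1 to compound 4 (0.15 log units; within the scatter) as the steps, so 2-methylphenyl, 4-fluorophenyl, 4-bromophenyl and 3-bromophenyl cannot be told apart by this read-out, and neither the kind of group on the ring nor the tested bromine placement shows a measurable effect among these four compounds. Nothing measured here offers an explanation for this flat result.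

Every group shown on the sulfonyl sulfur is a phenyl ring carrying a single methyl, fluoro or bromo group, so it remains open whether an amine or a carboxylic acid on that ring, or a longer alkyl chain in place of the ring, would shift the number. The compounds shown also leave open how changes away from this position, on the sulfonamide nitrogen or on the shared core, would read in this assay.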